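The compounds below may be only part of what the source reports. "The series", "measured", "known", "first", "only" and "open" are said of these compounds alone.

Measured so far:
- Compound 1 `CCN1Cc2c(ccc(C)c2C)C(c2ccccc2)C1`: 5300 nM
- Compound 2 `CNC(=O)N1Cc2c(ccc(C)c2C)C(c2ccccc2)C1`: "not determined" (no result reported)

The read-out is a functional assay on A2780 cells (Homo sapiens) for antiproliferative activity; on this read-out lower numbers stand for stronger inhibition and higher numbers for weaker inhibition. Within the data shown here, compound 2 has no number to stand on, so the only measured anchor is compound 1 at 5300 nM. Compound 3 `Cc1ccc2c(c1C)CN(C(=O)N(C)C)CC2c1ccccc1` departs from compound 2 by methyl in place of hydrogen on an amide-type nitrogen. Among the measured compounds shown here, no measured step shows what this methyl in place of hydrogen on an amide-type nitrogen does in this assay, so no shift beyond the scatter is expected in either direction from that anchor. Compound 3 is expected at about 6000 nM, with an estimated range of 1200 nM to 30000 nM.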

Compound 3, half-maximal inhibitory concentration: 1200 nM
Estimate against measurement, compound 3: 5.0-fold (0.70 log units) above; the measured number falls inside the stated range.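

In this assay, the amine nitrogen in a ring accepts dimethylcarbamoyl in place of ethyl, with a 4.4-fold lower number from compound 1 to compound 3 (0.65 log units; beyond the scatter), so a carbamoyl group at this position is compatible with a modest rise in antiproliferative activity. As far as these compounds go, the step that adds methyl in place of the amide hydrogen cannot be read, so the effect of that methyl alone remains unknown. Nothing available explains the difference. From the compounds shown here alone, whether an acetyl group or diethylcarbamoyl on this nitrogen would lower the number further remains open.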